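The source may report more compounds than this note shows. Statements on the series, on what has been measured and on what is new or still open speak of the compounds shown alone.

Compound 1 `CCOC(=O)C1=Cc2ccccc2OC1(OCc1cc(-c2ccc(Br)cc2)no1)C(F)(F)F` carries a 4-bromophenyl group. In a functional assay on DU-145 cells (Homo sapiens) for inhibition, read by MTT assay, with a stated time of 24 h (on this read-out lower numbers stand for stronger inhibition and higher numbers for weaker inhibition), compound 1 gives 71700 nM, the highest of the two numbers recorded; the nearest, compound 3 `CCOC(=O)C1=Cc2ccccc2OC1(OCc1cn(-c2ccc(F)c([N+](=O)[O-])c2)nn1)C(F)(F)F`, gives 13200 nM. Compound 2 `CCCCCCCCn1cc(COC2(C(F)(F)F)Oc3ccccc3C=C2C(=O)OCC)nn1` returns only a limit, > 150000 nM (the limit of > 150000 nM in this assay, at which 1 of the 3 values shown sits). Going by the values given here, the single measured step, an at least 11-fold lower number from compound 2 to compound 3 (1.05 log units; beyond the scatter), is large. Compound 4 `CCOC(=O)C1=Cc2ccccc2OC1(OCc1cc(-c2ccc([N+](=O)[O-])cc2)no1)C(F)(F)F` differs from compound 1 by nitro in place of bromo on an aromatic carbon. Among the compounds with values here, no measured step matches this change exactly, and the step from compound 2 to compound 3 swaps a whole chain for a ring with two substituents, so it bears only loosely. Compound 3 also carries nitro and gives 13200 nM. On that basis a modest lowering is expected, a 2.4-fold lower number from compound 1 to compound 4 (0.38 log units; beyond the scatter). Compound 4 is estimated at 30000 nM, between 8000 nM and 110000 nM.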

Compound 4, half-maximal inhibitory concentration: > 150000 nM
Compound 4 ended at the assay's limit (the forecaster's own chance of this, stated with the estimate: 10%); at least 5.0-fold (0.69 log units) between middle value and limit.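

Nitro in place of bromo, on an aromatic carbon para to a large group, gives an at least 2.0-fold higher number from compound 1 to compound 4 (0.32 log units; beyond the scatter) in this assay. This is the first change shown at this position of the 4-bromophenyl group, and it weakens inhibition rather than strengthening it. Compound 4 gives a limit and not a number, so this step shows only a minimum size: the limit of > 150000 nM in this assay, at which 2 of the 4 values shown sit.

As far as these compounds go, whether bromo itself is needed at this position stays open. The compounds shown do not tell how a chloro group or an amine in the same place would read.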